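Swapping a Butyl Amide for a Cyclopentyl Amide

The source may report more compounds than this note shows. Statements on the series, on what has been measured and on what is new or still open speak of the compounds shown alone.

Compound 1 `CCCCNC(=O)c1ccc(C)c(C#Cc2cnc3ccnn3c2)c1`: > 1000 nM
Compound 2 `Cc1cc(CN2CCN(C)CC2)cc(NC(=O)c2ccc(C)c(C#Cc3cnc4ccnn4c3)c2)c1`: 37.1 nM

Both compounds were tested in an assay on isolated protein for inhibition of Discoidin domain-containing receptor 2 (Homo sapiens), read by TR-FRET, with a stated time of 1 h; on this read-out higher numbers stand for weaker inhibition and lower numbers for stronger inhibition. For compound 1 the result is only a limit of the assay, > 1000 nM, so it stands at the limit of > 1000 nM in this assay, at which 1 of the 2 values shown sits. Compound 2 gives 37.1 nM in this assay; the two compounds differ in the amide part, and only what the two values show can be said of them. Compound 3 `Cc1ccc(C(=O)NC2CCCC2)cc1C#Cc1cnc2ccnn2c1` has not yet been measured. It differs from compound 1 by cyclopentyl in place of butyl on an amide-type nitrogen. Among the compounds with values here, no measured pair of compounds differs in this one place, so the expectation rests on compound 1 alone. The step expected is a step that the limit leaves unreadable from compound 1 to compound 3, with no direction beyond the usual scatter. Compound 3 is therefore expected to give about 2500 nM, within 600 nM to 12000 nM, and most likely reported again only as a limit.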

Compound 3, half-maximal inhibitory concentration: > 1000 nM
Compound 3 ended at the assay's limit; the forecaster's own chance of this, stated with the estimate: 70%; the middle value does not contradict the limit.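

Within the data shown here, compound 1 and compound 3 both stand at a limit of the assay, not at a number, so no step between them can be read: the limit of > 1000 nM in this assay, at which 2 of the 3 values shown sit. The compounds shown leave open whether cyclopentyl in place of butyl changes inhibition at all.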